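The source may report more compounds than this note shows. Statements on the series, on what has been measured and on what is new or still open speak of the compounds shown alone.

Working notes on the series. Compound 1 `COc1ccc([C@H]2OC[C@H]([C@@H](O)c3ccc(OC)c(OC)c3)C[C@@H]2C/C=C/c2ccccc2)cc1OC` gives 14800 nM in a functional assay on HeLa cells (Homo sapiens) for cytotoxicity, read by WST assay, with a stated time of 48 h; a lower number here means a stronger inhibitor, a higher number a weaker inhibitor. Compound 3 `COc1cccc(/C=C/C[C@H]2C[C@@H]([C@@H](O)c3ccc(OC)c(OC)c3)CO[C@@H]2c2ccc(OC)c(OC)c2)c1` differs from compound 1 by methoxy in place of hydrogen on an aromatic carbon; in this assay compound 3 gives 14000 nM, and the step is a 1.1-fold lower number from compound 1 to compound 3 (0.02 log units; within the scatter). Compound 2 `COc1cccc([C@H](O)[C@H]2CO[C@@H](c3ccc(OC)c(OC)c3)[C@H](C/C=C/c3ccc(OC)c(OC)c3)C2)c1` stands on a different core; the difference between the two cores is not broken down here. In this assay compound 2 gives 18600 nM, within the scatter of the other two numbers. Compound 4 `COc1ccc(/C=C/C[C@@H]2C[C@@H]([C@@H](O)c3ccc(OC)c(OC)c3)CO[C@H]2c2ccc(OC)c(OC)c2)cc1OC` is compound 2 with methoxy in place of hydrogen on an aromatic carbon, the same kind of change as from compound 1 to compound 3, though the surroundings differ: here the entering methoxy is ortho to a methoxy group and para to a large group, whereas in compound 3 it is meta to a large group. For the measured compounds named here, the one measured instance of this change is a 1.1-fold lower number from compound 1 to compound 3 (0.02 log units; within the scatter), a step within the scatter. On that basis the expected step is a 1.1-fold lower number from compound 2 to compound 4 (0.04 log units; within the scatter) in this assay. Compound 4 is therefore estimated at 17000 nM, with a range from 8000 nM to 36000 nM.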

Compound 4, half-maximal inhibitory concentration: 30600 nM
Estimate against measurement, compound 4: 1.8-fold (0.26 log units) below; the range from low to high includes it.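

In this assay, the new step is a 1.6-fold higher number from compound 2 to compound 4 (0.22 log units; within the scatter), and it lies within the scatter, as the earlier step does. Set side by side, the two steps do not differ beyond what two such steps would show by scatter: the same change on two cores in this assay, a 1.1-fold lower number (0.02 log units; within the scatter) from compound 1 to compound 3 and a 1.6-fold higher number (0.22 log units; within the scatter) from compound 2 to compound 4, 1.7-fold (0.24 log units) apart, within the scatter of two such steps

So, on these two cores, methoxy in place of hydrogen on an aromatic carbon gives no readable change, and no difference between the cores can be read; this rests on only two pairs, and it does not show that the change is without effect on other cores or that it would carry over in general.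

The compounds shown leave open whether any group in that place would move the number beyond the scatter, since the only substituents compared there are hydrogen and methoxy. An amine, a carboxylic acid or a longer alkoxy chain in place of that methoxy would test this.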